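Swapping a Methyl for a Pyrrolidine Amide

The compounds below may be only part of what the source reports. "The series", "measured", "known", "first", "only" and "open" are said of these compounds alone.

The set around compound 3 (`CCOc1ccc(-c2cccc(C)c2)cc1`) is small. In an assay on COS-7 cells for inhibition of patatin-like phospholipase domain-containing protein 2 (Mus musculus), tested at 200 uM (on this read-out lower numbers stand for less inhibition and higher numbers for more inhibition at the one concentration tested (going by the name of the read-out)), compound 3 gives 54%, the second highest of the three numbers recorded. Compound 1 (`CCOC(=O)C1CCCC(c2ccc(OCC)cc2)N1`) gives 48% in this assay, a number that lies within the scatter of compound 3, so no order can be drawn between the two. Compound 2 (`CCOC(=O)c1cccc(-c2ccc(OC)cc2)c1`), which carries an ethyl ester on one of its rings, gives 77% in this assay, a number beyond the scatter above compound 3.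

Compound 4 (`CCOc1ccc(-c2cccc(C(=O)N3CCCC3)c2)cc1`) has not yet been measured. It differs from compound 3 in one place: (pyrrolidin-1-yl)carbonyl in place of methyl on an aromatic carbon. For the measured compounds named here, no pair of measured compounds differing in a single place is available, so no measured step can guide the expectation. Going by the values given here, the only foothold is compound 2, whose ester on an aromatic ring resembles the carbonyl-bearing group that enters compound 4. In this assay compound 2 gives 77%. On that basis the step of a number 16 percentage points higher from compound 3 to compound 4 (beyond the scatter) is expected to be upward and beyond the scatter, though with wide uncertainty. Compound 4 is therefore estimated to give about 70% in this assay, with a range from 50% to 88%.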

Compound 4, a percentage reported as inhibition, at one concentration (the size of the read-out at that concentration, not a potency): 53%
The estimate for compound 4 lay 17 percentage points above the measured number; the range from low to high includes it.
By their numbers in this assay, from the lowest: compounds 1, 4 and 3 (each within the scatter of the next); then compound 2.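

For the compounds shown here, the replacement of methyl by (pyrrolidin-1-yl)carbonyl on an aromatic carbon, meta to a group of 9 heavy atoms, gives a number 1 percentage points lower from compound 3 to compound 4 (within the scatter) in this assay, and this is the first measured step in the set that changes a single place. It shows that this position carries the much larger group, with 7 heavy atoms in place of 1, including a five-membered non-aromatic ring and a hydrogen-bond acceptor, and that the read-out at the one concentration tested does not separate it from methyl. Nothing on hand offers an account of why these two groups read alike at this position.

As far as these compounds go, whether the carbonyl or the pyrrolidine ring has any separate bearing on the number stays open, and a carboxylic acid, a primary amide, a dimethylamide or a piperidine amide at the same place would bear on that question. Also open, from the compounds shown here alone, is whether compound 3 and compound 4 would stay this close at other concentrations, as a number from a single concentration is not a potency.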